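From methyl to methoxy: a step still unmeasured

This account rests on a few compounds, and the source may have more. Where it says the series, first, only, none or still open, it means among the compounds named here.

Measured so far in an ADME assay on microsomes from liver (Homo sapiens), read by LC-MS, using NADPH, with a stated time of 10 min, tested at 0.5 uM; a higher number here means that more of the compound is left, a lower number that less of the compound is left
- compound 1 `Cc1nc2cc(-c3cccc(-c4ccccc4)c3)nn2c(-c2cc(F)c3c(c2C)CCCO3)c1[C@H](OC(C)(C)C)C(=O)O` gives 78%
- compound 2 `Cc1ccccc1-c1cccc(-c2cc3nc(C)c([C@H](OC(C)(C)C)C(=O)O)c(-c4cc(F)c5c(c4C)CCCO5)n3n2)c1` gives 95%

Compound 2 holds the higher of these two numbers, and it sits near the top of what this assay can show. In compound 3 `COc1ccccc1-c1cccc(-c2cc3nc(C)c([C@H](OC(C)(C)C)C(=O)O)c(-c4cc(F)c5c(c4C)CCCO5)n3n2)c1` methoxy takes the place of methyl on an aromatic carbon, ortho to a large group, a change counted as methoxy in place of methyl on an aromatic carbon and reading 2-methylphenyl to 2-methoxyphenyl.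

Going by the values given here, only one measured step bears on this change, the one that brought in the methyl: a number 17 percentage points higher from compound 1 to compound 2 (beyond the scatter) for methyl in place of hydrogen. That step shows the number can move with a change at this carbon. Among the compounds with values here, no compound yet carries methoxy there, so the data cannot fix the direction. With compound 2 at 95% there is far more room to fall than to rise, so a small fall is expected, perhaps not beyond the scatter. The estimated change is a number 9 percentage points lower from compound 2 to compound 3 (within the scatter) in this measure. The expected value for compound 3 is 86% with an estimated range from 70% to 97% on repeated measurement.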

Compound 3, percent of the compound remaining: 99%
Compound 3: the middle estimate sits 13 percentage points below what was measured; the measured number lies above the stated range.
By their numbers in this assay, from the lowest: compound 1; then compounds 2 and 3 (each within the scatter of the next).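

In this assay, the change from 2-methylphenyl to 2-methoxyphenyl gives a number 4 percentage points higher from compound 2 to compound 3 (within the scatter) and so does not separate the two groups, even though methoxy adds one heavy atom, an oxygen, and one hydrogen-bond acceptor. The earlier compounds shown here tied a gain over hydrogen at this carbon to methyl alone, whereas a number 21 percentage points higher from compound 1 to compound 3 (beyond the scatter) now shows a gain beyond the scatter with a second group in the same place. The compounds shown offer no independent measurement that could say why methyl and methoxy read alike here.

Two small groups are a narrow sample, and with compound 3 at 99% this measure has little room left to show any further rise, so a real difference between groups that both read this high could stay hidden. On these data alone, it remains open whether the number would hold with a larger or charged group on this aromatic carbon, such as an amine or a carboxylic acid, or whether it would fall back towards the value of compound 1 at 78%.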